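The source may report more compounds than this note shows. Statements on the series, on what has been measured and on what is new or still open speak of the compounds shown alone.

Four compounds that share a common core are compared here. Compound 1 `COc1ccc(-c2ccnc(Nc3ccc(C(N)=O)cc3)n2)cc1` and compound 2 `COc1ccc(-c2ccnc(Nc3ccc(S(N)(=O)=O)cc3)n2)cc1` differ only in one group, as do compound 3 `CC(=O)Nc1ccc(-c2ccnc(Nc3cccc(S(N)(=O)=O)c3)n2)cc1` and compound 4 `CC(=O)Nc1ccc(-c2ccnc(Nc3cccc(C(N)=O)c3)n2)cc1`, the last of which is not yet measured. The read-out is an ADME assay on Vero cells (Chlorocebus sabaeus) for cytotoxicity, read by MTT assay, with a stated time of 72 h; on this read-out higher numbers stand for weaker inhibition and lower numbers for stronger inhibition.

Compound 2 gives 2400 nM in this assay, and compound 1 gives 5400 nM. The step between them, a 2.3-fold higher number from compound 2 to compound 1 (0.35 log units; beyond the scatter), comes from the change (carbamoyl in place of sulfamoyl on an aromatic carbon). Compound 3 gives 8700 nM, the highest of the three numbers; it lies within the scatter of the number for compound 1 but beyond the scatter of the number for compound 2. The difference between the core of compound 3 and the core of compound 2 is not broken down here.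

The change from compound 3 to compound 4 is carbamoyl in place of sulfamoyl on an aromatic carbon. Among the compounds with values here, it is the same kind of change as the one from compound 2 to compound 1, not the same: in the earlier pair the group stands para to a large group, in this pair it stands meta to a large group.

Resting on the step of a 2.3-fold higher number from compound 2 to compound 1 (0.35 log units; beyond the scatter), a rise of similar size is expected for compound 4, namely a 1.7-fold higher number from compound 3 to compound 4 (0.24 log units; within the scatter). Because compound 3 already gives 8700 nM, compound 4 is expected to give about 15000 nM, with a likely range from 6000 nM to 40000 nM.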

Compound 4, half-maximal inhibitory concentration: > 100000 nM
Compound 4: no number, only a limit; the forecaster's own chance of this, stated with the estimate: 20%; middle value at least 6.6-fold (0.82 log units) from the limit.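

The change of sulfamoyl to carbamoyl on an aromatic carbon, on the core of compound 3, gives an at least 11-fold higher number from compound 3 to compound 4 (1.06 log units; beyond the scatter) in this assay. For compound 4, the > 100000 nM is a limit of the assay and not a number, so the step has a lower bound but no known full size: the limit of > 100000 nM in this assay, at which 1 of the 4 values shown sits. The number rises on both cores, so the direction of the change carries over, but its size does not, and the pairs shown do not tell which difference between the two cores goes with the gap: the same change on two cores in this assay, a 2.3-fold higher number (0.35 log units; beyond the scatter) from compound 2 to compound 1 and an at least 11-fold higher number (1.06 log units; beyond the scatter) from compound 3 to compound 4, at least 5.1-fold (0.70 log units) apart, beyond the scatter of two such steps.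

Within the data shown here, with only two pairs, this comparison cannot say whether the same change would give a small or a large step on a third core, and it gives no exact size for the step on the core of compound 3. Also open, going by these compounds, is how other groups at the same place on the core of compound 3, such as a carboxylic acid, a nitrile or a methylsulfonyl group, would stand in this assay relative to compound 3 and compound 4.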